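The source may report more compounds than this note shows. Statements on the series, on what has been measured and on what is new or still open speak of the compounds shown alone.

Series notes. Compound 1 `CC1=CCC[C@H]2[C@](C)(CC3=CC(=O)C=CC3=O)[C@@H](C)CC[C@]12C` gives 4800 nM in an ADME assay on PBMC cells (Homo sapiens) for cytotoxicity, read by MTT assay; on this read-out higher numbers stand for weaker inhibition and lower numbers for stronger inhibition. Compound 2 `COC1=CC(=O)C=C(C[C@]2(C)[C@@H](C)CC[C@]3(C)C(C)=CCC[C@@H]23)C1=O` gives 5900 nM in this assay, the step being a 1.2-fold higher number from compound 1 to compound 2 (0.09 log units; within the scatter). Compound 3 `CC1=CCC[C@H]2[C@](C)(CC3=CC(=O)C=C(Sc4ccccc4)C3=O)[C@@H](C)CC[C@]12C` has "not determined" (no result reported) in this assay, so it stands on no number. Compound 4 `CNC1=CC(=O)C=C(C[C@]2(C)[C@@H](C)CC[C@]3(C)C(C)=CCC[C@@H]23)C1=O` differs from compound 3 by methylamino in place of phenylsulfanyl on a double-bonded ring carbon. Among the compounds with values here, no measured step spans this change; the one step seen, a 1.2-fold higher number from compound 1 to compound 2 (0.09 log units; within the scatter), alters the same ring position and stays within the scatter, but it runs from hydrogen to methoxy rather than from phenylsulfanyl to methylamino, so it bears only loosely. With compound 3 unmeasured, the expectation rests on compounds 1 and 2 and leans towards no step beyond the scatter from their range. Compound 4 is expected to give about 5500 nM in this assay, within 2000 nM to 15000 nM.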

Compound 4, half-maximal inhibitory concentration: 4900 nM
Compound 4: middle estimate off by 1.1-fold (0.05 log units), on the high side, within the range that was stated.
By their numbers in this assay, from the lowest: compounds 1, 4 and 2 (each within the scatter of the next).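

In this assay, methylamino on this double-bonded ring carbon gives no separation from methoxy (a 1.2-fold lower number from compound 2 to compound 4 (0.08 log units; within the scatter)) or from hydrogen (a 1.0-fold higher number from compound 1 to compound 4 (0.01 log units; within the scatter)). Within the data shown here, the position now carries a hydrogen-bond donor as well, and all three groups stay within the scatter of one another, which the single earlier step could not show. No evidence on hand explains this flat reading. Going by these compounds, whether a carboxylic acid or a longer amine chain on this carbon would give a step beyond the scatter stays open. So does whether any such step would hold on a changed core.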